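Halogen substitution on the central aryl ring of the ether series

A few compounds are considered here, and "the series" means these few. Any claim that something is new, unique, unknown or untested is made for them only; others in the source may bear on it.

Measured so far in a functional assay on CHO cells for positive allosteric modulation of metabotropic glutamate receptor 2 (Homo sapiens), read by scintillation counting and GTPgammaS binding, with a stated time of 30 min; a lower number here means that less compound is needed, a higher number that more compound is needed for the effect:
compound 1 `CCCCn1ccc(-c2ccc(Oc3ccnc(C)c3)cc2)c(C#N)c1=O`, 398 nM
compound 2 `CCCCn1ccc(-c2ccc(Oc3cccnc3C)cc2)c(C#N)c1=O`, 347 nM
compound 3 `CCCCn1ccc(-c2ccc(Oc3ccnc(C)c3)cc2Cl)c(C#N)c1=O`, 933 nM

Compound 1 stands second highest of the three numbers. Moving the ether partner gives a 1.1-fold lower number from compound 1 to compound 2 (0.06 log units; within the scatter), so the pyridyl change is silent. Placing a halogen on the central carbon ring gives a 2.3-fold higher number from compound 1 to compound 3 (0.37 log units; beyond the scatter), a modest loss.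

Compound 4 `CCCCn1ccc(-c2ccc(Oc3ccnc(C)c3)c(F)c2)c(C#N)c1=O` differs from compound 1 by fluoro in place of hydrogen on an aromatic carbon. For the measured compounds named here, only the step from compound 1 to compound 3 bears on it, as a halogen entering the same ring, though at a different carbon, and that step was modest. A step of similar or smaller size toward a higher number is expected, perhaps within the scatter. Compound 4 is therefore estimated at 550 nM, range 250 nM to 1200 nM, an expected step of a 1.4-fold higher number from compound 1 to compound 4 (0.14 log units; within the scatter).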

Compound 4, half-maximal effective concentration: 316 nM
Estimate against measurement, compound 4: 1.7-fold (0.24 log units) above; the measured number falls inside the stated range.
By their numbers in this assay, from the lowest: compounds 4, 2 and 1 (each within the scatter of the next); then compound 3.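

Fluoro ortho to the (2-methylpyridin-4-yl)oxy group is tolerated, with a 1.3-fold lower number from compound 1 to compound 4 (0.10 log units; within the scatter) as the step. The modest loss of a 2.3-fold higher number from compound 1 to compound 3 (0.37 log units; beyond the scatter) with chloro therefore does not extend to every halogen on the central ring, although halogen and ring carbon both differ between these two steps, so neither can be singled out. Nothing available explains the difference between the two steps.

Still open, as far as these compounds go, is how chloro, methyl or methoxy would behave at the fluoro-bearing carbon. Also open, from the compounds shown here alone, is whether fluoro at this carbon would carry over to the 2-methylpyridin-3-yl ether of compound 2.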